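From a Pyrimidine Ring to a Short Ether Chain

This account rests on a few compounds, and the source may have more. Where it says the series, first, only, none or still open, it means among the compounds named here.

Of the compounds shown here, three sharing one core have been measured in a functional assay on corpus cavernosum (Oryctolagus cuniculus); on this read-out lower numbers stand for an effect already at smaller amounts and higher numbers for an effect only at larger amounts of compound. Compound 1 `COc1ccc(CNc2cc(OCc3ccccn3)ccc2C(=O)c2cc(OC)c(OC)c(OC)c2)cc1Cl` gives in this assay only a limit, > 100 nM. Compound 2 `COc1ccc(CNc2nc(OCc3ccccc3)ncc2C(=O)c2cc(OC)c(OC)c(OC)c2)cc1Cl` likewise gives only a limit, > 100 nM. Among the measured compounds shown here, compound 3 `COc1ccc(CNc2nc(OCc3ncccn3)ncc2C(=O)c2cc(OC)c(OC)c(OC)c2)cc1Cl` is the single compound with a real number: in this assay compound 3 gives 3.1 nM, while the other two sit at the limit of > 100 nM in this assay, at which 2 of the 3 values shown sit. For the measured compounds named here, the one step between measured compounds that differ in a single place, an at least 32-fold lower number from compound 2 to compound 3 (1.50 log units; beyond the scatter), shows that the group at this position can shift the result strongly.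

Compound 4 `COCCOc1ncc(C(=O)c2cc(OC)c(OC)c(OC)c2)c(NCc2ccc(OC)c(Cl)c2)n1` has not yet been measured. It differs from compound 3 by methoxymethyl in place of pyrimidin-2-yl on a saturated chain carbon bound to an oxygen on an aromatic ring. Going by the values given here, no measured step covers this exact exchange; the only step at the same place, an at least 32-fold lower number from compound 2 to compound 3 (1.50 log units; beyond the scatter), was large, so a sizeable move is possible here too. Since the entering chain carries no ring, a step toward higher numbers is expected, estimated as a 9.7-fold higher number from compound 3 to compound 4 (0.99 log units; beyond the scatter). Compound 4 is therefore expected to give about 30 nM, within a range from 5 nM to 200 nM, with a real chance that this assay reports only a limit.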

Compound 4, half-maximal effective concentration: 10 nM
Compound 4: the middle estimate sits 3.0-fold (0.48 log units) above what was measured; low and high end bracket the measured number.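

A ring on this chain is not required for a low number in this assay: exchanging pyrimidin-2-yl for methoxymethyl, which has no ring, gives a 3.2-fold higher number from compound 3 to compound 4 (0.51 log units; beyond the scatter), a modest change that is still beyond the scatter. Measured against the phenyl group, the same ringless chain gives an at least 10-fold lower number from compound 2 to compound 4 (1.00 log units; beyond the scatter), so among compounds 2, 3 and 4 the presence of a ring does not by itself decide the result, as the two ring-bearing compounds 2 and 3 lie far apart. The value of compound 2 is only a limit, not a number: the limit of > 100 nM in this assay, at which 2 of the 4 values shown sit.

The compounds shown leave open how a longer ether chain, a chain carrying an amine, or one ending in a carboxylic acid would behave at this place. They also do not explain why phenyl and pyrimidin-2-yl differ so strongly.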